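The compounds below may be only part of what the source reports. "The series", "measured", "known", "first", "only" and "open" are said of these compounds alone.

Three compounds that differ only in the group on a ring nitrogen of the shared core have been tested in a functional assay on A549 cells (Homo sapiens) for antiproliferative activity, read by MTT assay, with a stated time of 72 h; on this read-out higher numbers stand for weaker inhibition and lower numbers for stronger inhibition. Compound 1 `CN1CCN(C(=S)SCc2ccc3nc(N)nc(N)c3c2)CC1`, with a methyl there, gives 9200 nM. Compound 2 `Nc1nc(N)c2cc(CSC(=S)N3CCN(c4ccccc4)CC3)ccc2n1`, with a phenyl, gives 2970 nM. Compound 3 `Cc1ccccc1N1CCN(C(=S)SCc2ccc3nc(N)nc(N)c3c2)CC1`, with a 2-methylphenyl, gives 3920 nM, the second highest of the three numbers. It cannot be told apart from compound 2, and both have lower numbers than compound 1.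

Within the data shown here, compound 4 `Nc1nc(N)c2cc(CSC(=S)N3CCN(c4ccc(Cl)c(Cl)c4)CC3)ccc2n1` keeps the core and changes only that group: 3,4-dichlorophenyl in place of 2-methylphenyl on an amine nitrogen in a ring. In words, a 3,4-dichlorophenyl takes the place of the 2-methylphenyl on the amine nitrogen in the ring.

Among the measured compounds shown here, three measured steps bear on this change. Swapping methyl for a phenyl gave a 3.1-fold lower number from compound 1 to compound 2 (0.49 log units; beyond the scatter), and swapping it for a 2-methylphenyl gave a 2.3-fold lower number from compound 1 to compound 3 (0.37 log units; beyond the scatter), both modest. Adding the methyl to the phenyl gave a 1.3-fold higher number from compound 2 to compound 3 (0.12 log units; within the scatter), the only change made on the phenyl itself. For the measured compounds named here, no measured compound carries chlorine, so this evidence is indirect. Compound 4 still has a substituted phenyl on that nitrogen, so a step beyond the scatter is not expected in this assay.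

The expected change is a 1.4-fold lower number from compound 3 to compound 4 (0.15 log units; within the scatter). For compound 4 the estimated value is 2800 nM, with an expected range of 1000 nM to 7000 nM.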

Compound 4, half-maximal inhibitory concentration: 2940 nM
Beside the measured number, compound 4's estimate is 1.1-fold (0.02 log units) below it, and the stated range covers the measured number.
By their numbers in this assay, from the lowest: compounds 4, 2 and 3 (each within the scatter of the next); then compound 1.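

In this assay, the 3,4-dichlorophenyl on the amine nitrogen in the ring reads the same as the two earlier aromatic groups, with a 1.3-fold lower number from compound 3 to compound 4 (0.12 log units; within the scatter) and a 1.0-fold lower number from compound 2 to compound 4 (0.00 log units; within the scatter), so among these three compounds neither the two chlorine atoms nor the methyl on the phenyl moves the number beyond the scatter. The separation from the methyl-bearing compound also holds with chlorine on the ring, as a 3.1-fold lower number from compound 1 to compound 4 (0.50 log units; beyond the scatter) shows, and compounds 2, 3 and 4 now all sit beyond the scatter on the lower side of compound 1. Nothing available here accounts for why these three aromatic groups read alike or why they differ from the methyl.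

The compounds shown leave open whether this flat reading would survive other groups on the phenyl, such as a methoxy, an amine or a carboxylic acid. They also leave open whether an aromatic ring is needed on that nitrogen at all, since a cyclohexyl, a benzyl or a longer chain such as butyl could separate the effect of the ring from that of simple size.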